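The source may hold more compounds than are shown below. What is called first, only, known or untested is meant among the compounds shown, and "the series" means these compounds.

Compound 1 `Cc1cccc(NS(=O)(=O)c2ccc(N3CCNC3=O)cc2)c1`: 200 nM
Compound 2 `CCc1cccc(NS(=O)(=O)c2ccc(N3CCNC3=O)cc2)c1`: 200 nM
Compound 3 `Cc1ccc(C)c(NS(=O)(=O)c2ccc(N3CCNC3=O)cc2)c1`: 74 nM

In a functional assay on CCRF-CEM cells (Homo sapiens) for antiproliferative activity, read by sulforhodamine B assay, with a stated time of 48 h (on this read-out higher numbers stand for weaker inhibition and lower numbers for stronger inhibition), compound 3 gives 74 nM, the lowest of the three numbers, which makes it the most potent of this small set. Compound 4 `O=C1NCCN1c1ccc(S(=O)(=O)Nc2cccc(Cl)c2)cc1` has not yet been measured. It differs from compound 3 in one place: 3-chlorophenyl in place of 2,5-dimethylphenyl on a sulfonamide nitrogen. In words, this is 3-chlorophenyl in place of 2,5-dimethylphenyl on a sulfonamide nitrogen.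

Going by the values given here, three measured steps bear on this change. Methyl in place of hydrogen on a saturated chain carbon left the number unmoved, with no change at the digits printed from compound 1 to compound 2 (within the scatter). Methyl in place of hydrogen on an aromatic carbon did more, with a 2.7-fold lower number from compound 1 to compound 3 (0.43 log units; beyond the scatter). Swapping the whole group gave a similar result, with a 2.7-fold lower number from compound 2 to compound 3 (0.43 log units; beyond the scatter).

Compound 1, at 200 nM, lacks the 2,5-dimethylphenyl group, and compound 2, at 200 nM, lacks it too. Compound 4 lacks it as well, which points to a modest move back towards higher numbers in this assay. No compound with chlorine has been measured, and the range is kept wide for that reason. The expected change is a 2.3-fold higher number from compound 3 to compound 4 (0.36 log units; beyond the scatter). For compound 4 the estimated value is 170 nM, with an expected range of 70 nM to 420 nM.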

Compound 4, half-maximal inhibitory concentration: 77 nM
For compound 4 the middle estimate is 2.2-fold (0.34 log units) above the measured one, within the range that was stated.
By their numbers in this assay, from the lowest: compounds 3 and 4 (each within the scatter of the next); then compounds 1 and 2 (each within the scatter of the next).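

In this assay, chloro in place of methyl gives a 2.6-fold lower number from compound 1 to compound 4 (0.41 log units; beyond the scatter), and chloro in place of ethyl gives a 2.6-fold lower number from compound 2 to compound 4 (0.41 log units; beyond the scatter), so a change of atom type on the aromatic ring moves the number, whereas methyl in place of hydrogen on the chain, which turned the methyl group into ethyl, did not. Going by these compounds alone, the 2,5-dimethylphenyl group is also not the only group on the sulfonamide nitrogen that reaches this level: 3-chlorophenyl in place of it gives a 1.0-fold higher number from compound 3 to compound 4 (0.02 log units; within the scatter), a step within the scatter, so the two groups cannot be told apart in this assay even though 3-chlorophenyl carries a single group on its ring and 2,5-dimethylphenyl carries two. No measured evidence bears on why chloro and methyl behave differently here.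

The compounds shown leave open whether 2,5-dichlorophenyl, which would combine the chlorine with the pattern of compound 3, would give a lower number than either compound 3 or compound 4. They also leave open how the number would respond to a different kind of group on that ring, such as a methoxy group, an amine or a carboxylic acid.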